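A few compounds are considered here, and "the series" means these few. Any claim that something is new, unique, unknown or untested is made for them only; others in the source may bear on it.

Compound 1 `CN(C)CCNC(=O)c1ccccc1Sc1cccc2ccccc12`: in an assay for inhibition of protein arginine N-methyltransferase 1 (Rattus norvegicus), read by scintillation counting, with stated times of 15 min and 60 min, in the presence of a further agent that is not named here (on this read-out higher numbers stand for weaker inhibition and lower numbers for stronger inhibition), compound 1 gives > 200000 nM
Compound 2 `CN(C)CCNC(=O)c1ccccc1Sc1ccccc1`: in this assay compound 2 gives > 50000 nM

Compound 1 stands only at a limit of this assay, which is all that the limit of > 200000 nM in this assay, at which 1 of the 2 values shown sits, reports. Compound 2 likewise sits at a limit, as the limit of > 50000 nM in this assay, at which 1 of the 2 values shown sits, states. Among the measured compounds shown here, no numerical step between the two measured compounds can therefore be read, and neither gives a real figure to anchor a change.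

Compound 3 `CN(C)CCNCc1ccccc1Sc1cccc2ccccc12` differs from compound 1 in one place: ((2-(dimethylamino)ethyl)amino)methyl in place of (2-(dimethylamino)ethyl)carbamoyl on an aromatic carbon. Since compound 1 reaches only a limit, the step of an at least 2.0-fold lower number from compound 1 to compound 3 (0.30 log units; that floor lies within the scatter) is an expectation without a measured counterpart, and the most plausible outcome is that compound 3 again falls at or near a limit rather than showing a clear gain. The estimate for compound 3 in this assay is 100000 nM, with an expected range from 20000 nM to 500000 nM.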

Compound 3, half-maximal inhibitory concentration: 34000 nM
The estimate for compound 3 lay 2.9-fold (0.47 log units) above the measured number; the measured number falls inside the stated range.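

In this assay, the exchange of (2-(dimethylamino)ethyl)carbamoyl for ((2-(dimethylamino)ethyl)amino)methyl on this aromatic carbon gives an at least 5.8-fold lower number from compound 1 to compound 3 (0.76 log units; beyond the scatter). This shows that the position responds to a change in the group's linking atoms, with the carbonyl oxygen gone and the count of hydrogen-bond donors and acceptors unchanged, and compound 3 provides the first real figure, 34000 nM. As far as these compounds go, the step is only a floor, and its true size stays unknown, since compound 1 reports only a limit: the limit of > 200000 nM in this assay, at which 1 of the 3 values shown sits.

Among the compounds shown here, no step involving compound 2 can be read, so whether the same exchange would lower its number remains open. Also open, from the compounds shown here alone, is how a longer chain, an ether or a sulfonamide in this place would compare with the amine of compound 3.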